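Methyl for Trifluoromethyl, Once More, in Compound 4

The compounds below may be only part of what the source reports. "The series", "measured", "known", "first", "only" and "open" are said of these compounds alone.

Compound 1 `COc1ccc2nc(N(Cc3cc(-c4ccc(OC(F)(F)F)cc4)no3)c3nc4ccc(F)cc4s3)sc2c1` and compound 2 `COc1ccc(-c2cc(CN(c3nc4ccc(F)cc4s3)c3nc4ccc(OC)cc4s3)on2)cc1` share one core. In a functional assay on U-937 cells (Homo sapiens) for antiproliferative activity, read by MTT assay (on this read-out lower numbers stand for stronger inhibition and higher numbers for weaker inhibition), compound 1 gives 23100 nM, and compound 2 gives 138000 nM. The change between them, (methyl in place of trifluoromethyl on an oxygen on an aromatic ring), produced a 6.0-fold higher number from compound 1 to compound 2 (0.78 log units; beyond the scatter). Compound 3 `FC(F)(F)Oc1ccc(-c2cc(CN(c3ncccn3)c3nc4ccccc4s3)on2)cc1` is built on a different core; how the core of compound 3 differs from the core of compound 1 is not broken down here. In this assay compound 3 gives 13500 nM, a number within the scatter of compound 1 and beyond it from compound 2. Compound 4 `COc1ccc(-c2cc(CN(c3ncccn3)c3nc4ccccc4s3)on2)cc1` differs from compound 3 by methyl in place of trifluoromethyl on an oxygen on an aromatic ring, the same change that was made from compound 1 to compound 2, in the same place. Among the compounds with values here, a step of similar direction and roughly similar size is expected for compound 4, and that expectation rests on the earlier step of a 6.0-fold higher number from compound 1 to compound 2 (0.78 log units; beyond the scatter), which lay beyond the scatter, with the caution that only one example of the change is in hand and it was seen on another core. Compound 4 is therefore estimated to give 60000 nM in this assay. The step this implies is expected to be a 4.4-fold higher number from compound 3 to compound 4 (0.65 log units; beyond the scatter). Compound 4 is expected to fall between 25000 nM and 150000 nM.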

Compound 4, half-maximal inhibitory concentration: 13900 nM
Beside the measured number, compound 4's estimate is 4.3-fold (0.64 log units) above it; measured number outside the range, below it.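

In this assay, putting methyl in place of trifluoromethyl on the core of compound 3 gave a 1.0-fold higher number from compound 3 to compound 4 (0.01 log units; within the scatter), so on this core the change left the number within the scatter. Within the data shown here, the size of the step therefore did not carry over from one core to the other, and the two examples of the same change disagree: the same change on two cores in this assay, a 6.0-fold higher number (0.78 log units; beyond the scatter) from compound 1 to compound 2 and a 1.0-fold higher number (0.01 log units; within the scatter) from compound 3 to compound 4, 5.8-fold (0.76 log units) apart, beyond the scatter of two such steps This shows that a step seen on one core of this series cannot simply be transferred to another, but with only one pair on each core it does not show which feature of the cores goes with the gap, nor how the change would behave on any further core.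

The compounds shown leave open how a hydroxyl group, a chlorine atom or a longer chain such as ethoxy would read in the same place on either core. They also leave open whether a third pair on another core would follow the step seen on the core of compound 1 or the one seen on the core of compound 3.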